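A few compounds are considered here, and "the series" means these few. Any claim that something is new, unique, unknown or untested is made for them only; others in the source may bear on it.

Working notes on the series in a functional assay on MCF7 cells (Homo sapiens) for cytotoxicity, read by MTT assay, with a stated time of 72 h; on this read-out higher numbers stand for weaker inhibition and lower numbers for stronger inhibition.

For the measured compounds named here, compound 1 `N[C@H]1CC[C@H](Nc2c(C(=O)NCc3ccccn3)nc(Br)c3cccnc23)CC1` is the only member with a number in this assay: compound 1 gives 15000 nM. Compound 2 `O=C(NCc1ccc(F)cc1)c1nc(NCCO)c2cccnc2c1O` shares the amide-bearing core but differs at several places, and for compound 2 this assay returns "not determined" (no result reported), so it gives no footing for comparison. Going by the values given here, no pair of measured compounds differing in one place is available.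

Compound 3 `N[C@H]1CC[C@H](Nc2c(C(=O)NCc3cccs3)nc(Br)c3cccnc23)CC1` follows from compound 1 by the change (thiophen-2-yl in place of pyridin-2-yl on a saturated chain carbon bound to an amide-type nitrogen). Among the compounds with values here, the two aromatic groups on that chain carbon are comparable in size and each carries one hydrogen-bond acceptor; nothing among the measured compounds shows how this assay responds to such a swap. The step of no change at the digits printed from compound 1 to compound 3 (within the scatter) is therefore expected to stay within the scatter, with no direction preferred. Compound 3 is estimated at 15000 nM, in the range 5000 nM to 45000 nM.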

Compound 3, half-maximal inhibitory concentration: 7300 nM
Compound 3: the middle estimate sits 2.1-fold (0.31 log units) above what was measured, and the stated range covers the measured number.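

In this assay the place on a saturated chain carbon bound to an amide-type nitrogen proves sensitive to the aromatic group it carries: thiophen-2-yl in place of pyridin-2-yl gives a 2.1-fold lower number from compound 1 to compound 3 (0.31 log units; beyond the scatter) and so points toward stronger inhibition, though only modestly. The hydrogen-bond acceptor count of the group stays the same while the ring size and hetero atom change, so this place accepts a five-membered sulfur ring without any loss on this read-out. Nothing at hand ties the step to a property of either ring.

Open, from the compounds shown here alone, is whether phenyl, furan-2-yl or a longer chain at this place would move the number further. Also open, going by these compounds, is whether the same swap gives a like step when the shared core carries a carboxylic acid elsewhere.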